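The source may hold more compounds than are shown below. What is called first, only, known or untested is meant among the compounds shown, and "the series" means these compounds.

Compound 1, `COc1ccc(-c2cc(NC(=O)CCC(=O)N(C)CC(=O)NC3CCCCC3)nc(-c3ccc(OC)cc3)n2)cc1`: 52900 nM
Compound 2, `COc1ccc(-c2cc(NC(=O)COCC(=O)N(C)CC(=O)NC3CCCCC3)nc(-c3ccc(OC)cc3)n2)cc1`: 23700 nM
Compound 3, `COc1ccc(-c2cc(NC(=O)COCC(=O)N3CCN(CC(=O)NC4CCCCC4)CC3)nc(-c3ccc(OC)cc3)n2)cc1`: 16100 nM

These three compounds were tested in an assay on HeLa cells for displacement of a labelled ligand from adenosine receptor A3 (Homo sapiens), read by fluorescence polarization, with a stated time of 30 min; a higher number here means a weaker inhibitor, a lower number a stronger inhibitor. Compound 3 gives the lowest of the three numbers, but its gap to compound 2 lies within the usual scatter of repeated measurements, so the two cannot be told apart; only compound 1 stands clearly apart from compound 3, with the higher number. Compound 4, `COc1ccc(-c2cc(NC(=O)COCC(=O)N3CCN(CC(=O)NCc4ccccc4)CC3)nc(-c3ccc(OC)cc3)n2)cc1`, has not yet been measured in this assay. It keeps everything of compound 3 except one change: benzyl in place of cyclohexyl on an amide-type nitrogen. Within the data shown here, no pair among the measured compounds differs by this kind of exchange, so there is no measured step to lean on. Given that the compounds so far all sit in a narrow band of weak inhibition, the expected step, a 1.0-fold lower number from compound 3 to compound 4 (0.00 log units; within the scatter), is none beyond the scatter, in either direction. The value expected for compound 4 in this assay is therefore 16000 nM, with a range from 6000 nM to 45000 nM.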

Compound 4, inhibition constant: 33000 nM
For compound 4 the middle estimate is 2.1-fold (0.31 log units) below the measured one; low and high end bracket the measured number.
By their numbers in this assay, from the lowest: compounds 3, 2, 4 and 1 (each within the scatter of the next, the first and the last beyond it).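

Putting benzyl in place of cyclohexyl on the amide-type nitrogen gives a 2.0-fold higher number from compound 3 to compound 4 (0.31 log units; beyond the scatter) in this assay and makes compound 4 a modestly weaker inhibitor than compound 3. Among these compounds, this is the first sign that the group at this place affects the reading: here, a non-aromatic carbon ring and an aromatic one are not interchangeable, although the step is small. No measurement here gives a reason for this step.

As far as these compounds go, whether the difference follows the aromatic ring or the added carbon stays open: cyclohexylmethyl or phenyl on the same nitrogen would separate the two. Also open, from the compounds shown here alone, is whether a group carrying an amine or a carboxylic acid at this place would shift the number, and in which direction.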